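The source may report more compounds than this note shows. Statements on the series, on what has been measured and on what is new or still open speak of the compounds shown alone.

Measured so far in a functional assay on HL-60 cells (Homo sapiens) for antiproliferative activity, read by MTT assay, with a stated time of 72 h; on this read-out lower numbers stand for stronger inhibition and higher numbers for weaker inhibition:
- compound 1, `NC1=NC2(CCOCC2)N(OCCCOc2ccc(Cl)c(Cl)c2)C(N)=N1`: 1240 nM
- compound 2, `Cc1ccc(OCCCON2C(N)=NC(N)=NC23CCOCC3)cc1`: 2580 nM
- compound 3, `NC1=NC2(CCOCC2)N(OCCCOc2ccc(Cl)cc2)C(N)=N1`: 330 nM

Compound 1 stands second highest of the three numbers. Its nearest neighbour is compound 2, reached by a 2.1-fold higher number from compound 1 to compound 2 (0.32 log units; beyond the scatter), and its furthest is compound 3, reached by a 3.8-fold lower number from compound 1 to compound 3 (0.57 log units; beyond the scatter). Between the other two, a 7.8-fold lower number from compound 2 to compound 3 (0.89 log units; beyond the scatter) separates them.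

The step now followed leads from compound 1 to compound 4, `NC1=NC2(CCOCC2)N(OCCCOc2ccccc2)C(N)=N1`, through the change (phenyl in place of 3,4-dichlorophenyl on an oxygen on a saturated carbon). Within the data shown here, two measured steps bear on it. The step from compound 1 to compound 3, which also removes a chloro from the aromatic ring, gave a 3.8-fold lower number from compound 1 to compound 3 (0.57 log units; beyond the scatter), so removing chloro has so far lowered the number. Against this, the step from compound 2 to compound 3 gave a 7.8-fold lower number from compound 2 to compound 3 (0.89 log units; beyond the scatter), showing that a ring carrying chloro gave a lower number than one carrying methyl, so an unsubstituted phenyl need not continue the trend toward compound 3. Among the measured compounds shown here, no measured pair removes both chloro groups at once.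

On balance a modest lowering of the number is expected, but smaller than the step to compound 3, and with wide uncertainty: compound 4 is expected to move by a 1.8-fold lower number from compound 1 to compound 4 (0.25 log units; within the scatter) in this assay. Compound 4 is therefore estimated at 700 nM, with a range from 200 nM to 2500 nM.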

Compound 4, half-maximal inhibitory concentration: 2460 nM
Beside the measured number, compound 4's estimate is 3.5-fold (0.55 log units) below it, within the range that was stated.
By their numbers in this assay, from the lowest: compound 3; then compounds 1, 4 and 2 (each within the scatter of the next, the first and the last beyond it).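

In this assay, taking the remaining chloro off the aromatic ring gives a 7.5-fold higher number from compound 3 to compound 4 (0.87 log units; beyond the scatter) and so does not keep the low number of compound 3; the earlier steps had shown only that losing one chloro from compound 1 lowered the number. Neither a 2.0-fold higher number from compound 1 to compound 4 (0.30 log units; within the scatter) nor a 1.0-fold lower number from compound 2 to compound 4 (0.02 log units; within the scatter) lies beyond the scatter, so at this place, on an oxygen on a saturated carbon, phenyl cannot be told apart from 3,4-dichlorophenyl or from the methyl-bearing ring of compound 2, and the count of chloro groups does not order the numbers, since compound 3 with one chloro stands apart from both compound 1 with two and compound 4 with none. No measurement shown here accounts for what sets compound 3 apart.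

The compounds shown leave open whether that low number belongs to chloro alone or would also appear with a fluoro, a bromo or a methoxy on the aromatic ring. They also leave open whether it would survive a longer chain between the two oxygens or a different group in place of the shared core.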